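This account rests on a few compounds, and the source may have more. Where it says the series, first, only, none or still open, it means among the compounds named here.

Measured compounds:
- compound 1 `COC1=C(Br)[C@H](O)[C@@]2(C=C1Br)CC(C(=O)NCCCCCNC(=O)C1=NO[C@]3(C=C(Br)C(=O)[C@@H](Br)[C@@H]3O)C1)=NO2` gives 3300 nM in growth inhibition
- compound 2 `COC1=C(Br)[C@H](O)[C@@]2(C=C1Br)CC(C(=O)NCCCCNC(=O)C1=NO[C@]3(C=C(Br)C(=O)[C@@H](Br)[C@@H]3O)C1)=NO2` gives 3500 nM in growth inhibition

In a functional assay on MDA-MB-231 cells (Homo sapiens) for cytotoxicity, read by sulforhodamine B assay (a higher number here means a weaker inhibitor of growth, a lower number a stronger inhibitor of growth), compound 1 stands at 3300 nM and compound 2 at 3500 nM on the same read-out. These two numbers lie within the usual scatter of each other, so neither compound stands apart.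

Compound 3 `COC1=C(Br)[C@H](O)[C@@]2(C=C1Br)CC(C(=O)NCCCCCNC(=O)C1=NO[C@]3(C=C(Br)C(=O)[C@H](Br)[C@@H]3O)C1)=NO2` departs from compound 1 in one feature only: the two compounds have the same atoms and bonds and differ only in configuration as drawn: 1 of 5 stereo elements differ; a stereocentre at a saturated ring carbon is drawn S in compound 1 and R in compound 3. Nothing leaves and nothing enters, since a stereocentre at a saturated ring carbon is simply drawn S in compound 1 and R in compound 3.

For the measured compounds named here, no measured pair shows what such an inversion does, so the expectation in this assay is for no step beyond the scatter in either direction, though the range is kept wide. The estimated change is a 1.1-fold higher number from compound 1 to compound 3 (0.03 log units; within the scatter) on this evidence. For compound 3 the expected value is 3500 nM, with an estimated range from 1500 nM to 8000 nM.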

Compound 3, concentration for 50% growth inhibition: 3500 nM
Compound 3: the middle estimate sits on the measured number at the digits printed; low and high end bracket the measured number.
By their numbers in this assay, from the lowest: compounds 1, 2 and 3 (each within the scatter of the next).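

In this assay, inverting a stereocentre at a saturated ring carbon from S to R gives a 1.1-fold higher number from compound 1 to compound 3 (0.03 log units; within the scatter). For the compounds shown here, this is the first measured pair to isolate the configuration at this carbon, and the inversion does not move the number beyond the scatter. The comparison therefore bears on a single feature: the fact that compounds 1 and 3 differ only in the configuration as drawn

The compounds shown leave open whether the same inversion would be equally silent at any of the other stereo elements, or on the chain of compound 2. They also leave open whether a chlorine in place of a bromine, a longer chain, or an amine on the chain would shift the number, with either configuration at this carbon.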